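Swapping the Halogenated Benzyl Group on Compound 1

This account rests on a few compounds, and the source may have more. Where it says the series, first, only, none or still open, it means among the compounds named here.

In a functional assay on PC-9 cells (Homo sapiens) for inhibition, read by MTT assay, with a stated time of 72 h (a lower number here means a stronger inhibitor, a higher number a weaker inhibitor), compound 1 (`Cc1cc(Nc2cc(-c3ccccc3)[nH]n2)n2nc(SCc3c(Cl)cccc3Cl)nc2n1`) gives 5180 nM and compound 2 (`Cc1cc(Nc2ccn(Cc3cccc4ccccc34)n2)n2nc(SCc3ccc(Br)cc3)nc2n1`) gives 5660 nM, values within the scatter of each other. Compound 3 (`Cc1cc(Nc2ccn(Cc3ccccc3)n2)n2nc(SCc3ccc(Br)cc3)nc2n1`) gives > 50000 nM, which is a limit and not a number.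

Compound 4 (`Cc1cc(Nc2cc(-c3ccccc3)[nH]n2)n2nc(SCc3ccc(Br)cc3)nc2n1`) differs from compound 1 by 4-bromophenyl in place of 2,6-dichlorophenyl on a saturated chain carbon bound to a sulfur, with 4-bromophenyl in place of 2,6-dichlorophenyl on a saturated chain carbon bound to a sulfur. For the measured compounds named here, the only measured step is an at least 8.8-fold higher number from compound 2 to compound 3 (0.94 log units; beyond the scatter), but it lies on a saturated chain carbon bound to an aromatic nitrogen, so it does not test this change. Going by the values given here, no step at the sulfur side has been measured, so the expected result is a 1.2-fold higher number from compound 1 to compound 4 (0.06 log units; within the scatter), nothing beyond the scatter. For compound 4 the estimate is 6000 nM, with an expected range from 1500 nM to 25000 nM.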

Compound 4, half-maximal inhibitory concentration: 4760 nM
Estimate against measurement, compound 4: 1.3-fold (0.10 log units) above, and the stated range covers the measured number.
By their numbers in this assay, from the lowest: compounds 4, 1 and 2 (each within the scatter of the next). At a limit, above all of these: compound 3.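

The first step measured at the sulfur side, 4-bromophenyl in place of 2,6-dichlorophenyl on a saturated chain carbon bound to a sulfur, gives a 1.1-fold lower number from compound 1 to compound 4 (0.04 log units; within the scatter) in this assay. At this position, then, the assay does not tell these two halogenated groups apart, even though the halogen and its place on the ring both differ. No measurement shown here offers a cause for this result.

Still open, as far as these compounds go, is whether a plain benzyl group, a longer chain or a benzyl group carrying a carboxylic acid or an amine would read differently at this position.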